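Adding a Second Methyl to the Succinimide Ring

The source may hold more compounds than are shown below. What is called first, only, known or untested is meant among the compounds shown, and "the series" means these compounds.

Within the data shown here, the two compounds measured so far share a core in which a methyl-bearing five-membered imide is linked through an amide to an aryl piperazine. Compound 1 `CCC(C(=O)N1CCN(c2cccc(C(F)(F)F)c2)CC1)N1C(=O)CC(C)C1=O` carries a trifluoromethyl on the aryl ring and a longer chain at the linking carbon. In a functional assay on the whole organism (strain Swiss) with Mus musculus as the target, with a stated time of 0.5 h (a lower number here means that less compound is needed, a higher number that more compound is needed for the effect), compound 1 gives > 130 mg/kg, which is a limit of the assay rather than a number. Compound 1 thus sits at the limit of > 130 mg/kg in this assay, at which 1 of the 2 values shown sits. Compound 2 `CC1CC(=O)N(C(C)C(=O)N2CCN(c3cccc(Cl)c3)CC2)C1=O` carries a chloro substituent on the aryl ring and a shorter chain; in this assay compound 2 gives 121 mg/kg, the only number shown. Compound 3 `CC(C(=O)N1CCN(c2cccc(Cl)c2)CC1)N1C(=O)CC(C)(C)C1=O` has not yet been measured. It differs from compound 2 by methyl in place of hydrogen on a saturated ring carbon. Among the measured compounds shown here, with no measured step to lean on, the step from compound 2 to compound 3 is expected to be small, in either direction, not beyond the usual scatter. Compound 3 is therefore estimated at 125 mg/kg in this assay, within a range from 60 mg/kg to 250 mg/kg, an expected step of a 1.0-fold higher number from compound 2 to compound 3 (0.01 log units; within the scatter).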

Compound 3, dose for half-maximal effect: > 130 mg/kg
Compound 3 was reported as a limit (the forecaster's own chance of this, stated with the estimate: 35%); middle value at least 1.0-fold (0.01 log units) away from the limit.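

In this assay compound 3 gives > 130 mg/kg, which is a limit of the assay and not a number. Among these compounds, the methyl in place of hydrogen on this saturated ring carbon, two ring bonds from the ring nitrogen, provides the first change in a single place that can be read, and it gives an at least 1.0-fold higher number from compound 2 to compound 3 (0.03 log units; that floor lies within the scatter); this is only a floor, so the data show no change beyond the usual scatter, yet they also do not show that the methyl is tolerated without loss. The result also means that the limit is no longer reached by a single compound: the limit of > 130 mg/kg in this assay, at which 2 of the 3 values shown sit.

Going by these compounds, how far the true value of compound 3 lies past the limit remains unknown, so the real size of this step could be small or large. Also open, on these data alone, is whether an ethyl group, a hydroxyl group or an amine on the same saturated ring carbon would give a measurable number in this assay, rather than another limit.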